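Swapping a fluorobenzyl for a methoxyphenylamino on the core

The compounds below may be only part of what the source reports. "The series", "measured", "known", "first", "only" and "open" are said of these compounds alone.

Measured compounds:
- Compound 1, `CCc1ccccc1N(Cc1nnc(Cc2ccccc2)o1)S(=O)(=O)c1ccc(C)cc1`: 1000 nM
- Compound 2, `CCOc1ccc(Cc2nnc(CN(c3cccc(Cl)c3Cl)S(=O)(=O)c3ccc(C)cc3)o2)cc1`: 6.31 nM
- Compound 3, `Cc1ccc(S(=O)(=O)N(Cc2nnc(Cc3ccc(F)cc3)o2)c2cccc(Cl)c2C)cc1`: 200 nM

In an assay on CHO cells for displacement of a labelled ligand from prostaglandin E2 receptor EP1 subtype (Homo sapiens) (a higher number here means a weaker inhibitor, a lower number a stronger inhibitor), compound 3 sits second highest of the three numbers. Its nearest neighbour is compound 1, whose number is higher and beyond the scatter; compound 2 lies furthest away, with a lower number well beyond the scatter. Compound 4, `COc1ccc(Nc2nnc(CN(c3cccc(Cl)c3C)S(=O)(=O)c3ccc(C)cc3)o2)cc1`, has not yet been measured. It differs from compound 3 in one place: (4-methoxyphenyl)amino in place of 4-fluorobenzyl on an aromatic carbon. Among the measured compounds shown here, no measured pair shows this change, so the expectation rests on the spread between compound 3 and compound 2. Compound 4 is expected to give a modestly lower number, an estimated step of a 2.0-fold lower number from compound 3 to compound 4 (0.30 log units; within the scatter). The estimate for compound 4 in this assay is 100 nM, within 20 nM to 600 nM.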

Compound 4, half-maximal inhibitory concentration: 31.6 nM
Compound 4: middle estimate off by 3.2-fold (0.50 log units), on the high side; the measured number falls inside the stated range.
By their numbers in this assay, from the lowest: compound 2; then compound 4; then compound 3; then compound 1.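

In this assay, the group on this aromatic carbon of the five-membered ring clearly matters: (4-methoxyphenyl)amino in place of 4-fluorobenzyl gives a 6.3-fold lower number from compound 3 to compound 4 (0.80 log units; beyond the scatter), beyond the usual scatter. The change swaps both the link to the ring and the group on the six-membered ring, so this single step cannot show which of the two matters. Nothing measured here explains the shift. Still open, on these data alone, is how much each part contributes. (4-Fluorophenyl)amino, which keeps the fluorine but carries the new nitrogen link, would help separate them.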